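The source may hold more compounds than are shown below. What is called first, only, known or untested is meant among the compounds shown, and "the series" means these compounds.

Compound 1 `CC(C)OC(=O)N1CCC(Oc2ncnc3c2CCN3c2ccc(S(C)(=O)=O)cc2)CC1`: 154%
Compound 2 `CN(C)S(=O)(=O)N1CCC(Oc2ncnc3c2CCN3c2ccc(S(C)(=O)=O)cc2F)CC1`: 68%
Compound 3 `CC(C)OC(=O)N1CCC(Oc2ncnc3c2CCN3c2ccc(C#N)cn2)CC1`: 105%

In a functional assay on CHO-K1 cells with Glucose-dependent insulinotropic receptor (Homo sapiens) as the target, read by a luciferase reporter, with a stated time of 5 h (on this read-out lower numbers stand for smaller maximal responses and higher numbers for larger maximal responses), compound 3 gives 105%, the second highest of the three numbers, clear of compound 2 and clear of compound 1 in both directions. Going by the values given here, compound 4 `CC(C)OC(=O)N1CCC(Oc2ncnc3c2CCN3c2ccc([S@@+](C)[O-])c(F)c2)CC1` differs from compound 3 in one place: a group of 10 heavy atoms (7 carbon, 1 oxygen, 1 fluorine, 1 sulfur; one six-membered aromatic ring of carbon only) in place of a group of 8 heavy atoms (6 carbon, 2 nitrogen; one six-membered aromatic ring with 1 hetero atom), on a nitrogen on an aromatic ring in a ring The only measured step at this position is a number 49 percentage points lower from compound 1 to compound 3 (beyond the scatter), and the group that enters in compound 4 resembles the 4-(methylsulfonyl)phenyl of compound 1 more closely than the 5-cyanopyridin-2-yl of compound 3. Among the compounds with values here, compound 2 carries a related group but differs elsewhere as well, so its value gives no step. Compound 4 is therefore expected to move upward, a number 25 percentage points higher from compound 3 to compound 4 (beyond the scatter). For compound 4 the expected value is 130%, with a range from 95% to 165%.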

Compound 4, largest response reached (reported as percent of maximum), in percent of the reference or control that the assay uses: 155%
Compound 4: the middle estimate sits 25 percentage points below what was measured, and the stated range covers the measured number.
By their numbers in this assay, from the lowest: compound 2; then compound 3; then compounds 1 and 4 (each within the scatter of the next).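

In this assay the group entering in compound 4 recovers the height lost with 5-cyanopyridin-2-yl (a number 50 percentage points higher from compound 3 to compound 4 (beyond the scatter)) and stands level with 4-(methylsulfonyl)phenyl (a number 1 percentage points higher from compound 1 to compound 4 (within the scatter)). At this nitrogen, two different sulfur-bearing groups on a carbon-only aromatic ring thus give matching responses, and of compounds 1, 3 and 4, only compound 3 falls clearly lower. No measurement shown accounts for these differences. The compounds shown leave open what the fluorine and the defined stereocentre each contribute. They also leave open how an amine or a carboxylic acid on the aromatic ring would fare.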